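This account rests on a few compounds, and the source may have more. Where it says the series, first, only, none or still open, it means among the compounds named here.

Measured so far:
Compound 1 `C=CC(=O)N1CC[C@H](N2C(=O)N(c3ccccc3)Cc3cnc(Nc4cccc(N5CCN(C)CC5)c4)nc32)C1`: 20%
Compound 2 `C=CC(=O)N1CC[C@H](N2C(=O)N(c3ccccc3)Cc3cnc(Nc4ccc(N5CCN(C)CC5)cc4OC)nc32)C1`: 44%
Compound 3 `C=CC(=O)N1CC[C@H](N2C(=O)N(c3ccccc3)Cc3cnc(Nc4ccc(N5CCN(C)CC5)c(OC)c4)nc32)C1`: 20%

These three compounds share one core and have all been tested in an ADME assay on the whole organism (strain Sprague-Dawley) for pharmacokinetics, with Rattus norvegicus as the target, read by LC-MS, at a dose of 25 mg/kg by the oral route; on this read-out lower numbers stand for lower oral bioavailability and higher numbers for higher oral bioavailability. In this assay compound 1 gives 20%, compound 2 gives 44% and compound 3 gives 20%. Compound 3 thus stands level with compound 1 at the digits shown, a gap that lies within the usual scatter, and the two together hold the lowest number of the three. Compound 2 stands furthest from compound 3, with a number that is higher by a margin beyond the scatter.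

Compound 4 `C=CC(=O)N1CC[C@H](N2C(=O)N(c3ccccc3)Cc3cnc(Nc4ccc(N5CCN(C)CC5)c(C)c4)nc32)C1` has not yet been measured in this assay. It differs from compound 3 in a single place: methyl in place of methoxy on an aromatic carbon. For the measured compounds named here, no measured pair shows this same exchange, so there is no step to lean on; the only anchor is that compound 3 sits at the low end of the three. A change of this size is expected to shift the number little, with no clear direction, so the expected step of a number 2 percentage points higher from compound 3 to compound 4 (within the scatter) is small and most likely within the scatter. Compound 4 is therefore expected to give 22%, within a range from 8% to 40%.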

Compound 4, oral bioavailability in the Rattus norvegicus assay: 30%
Compound 4: the middle estimate sits 8 percentage points below what was measured; low and high end bracket the measured number.
By their numbers in the Rattus norvegicus assay, from the lowest: compounds 1, 3 and 4 (each within the scatter of the next); then compound 2.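

In the Rattus norvegicus assay, putting methyl in place of methoxy on the aromatic carbon ortho to the 4-methylpiperazin-1-yl group gives a number 10 percentage points higher from compound 3 to compound 4 (within the scatter), so on oral bioavailability this position accepts the exchange without a clear separation between the two compounds. For the compounds shown here, in a physicochemical assay for solubility, read by HPLC, in phosphate buffer, measured as thermodynamic solubility, with a stated time of 24 h, at pH 6.8 (on this read-out lower numbers stand for lower solubility and higher numbers for higher solubility), a read-out that the earlier comparisons did not include, compound 3 gives 256 ug/mL and compound 4 gives 1270 ug/mL, so the two compounds do separate on this second measure. For this one pair, the higher solubility that comes with methyl in place of methoxy is not matched by a step beyond the scatter in oral bioavailability: the measured solubility of compound 3, 256 ug/mL, and of compound 4, 1270 ug/mL, a 5.0-fold higher number (0.70 log units; beyond the scatter)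

From the compounds shown here alone, what stays open is whether another group on this same aromatic carbon, such as a chlorine atom, a nitrile or a hydroxyl group, would give the same picture on both read-outs. A single pair also cannot show why solubility differs, or whether the same exchange would behave alike elsewhere on the shared core.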